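The source may report more compounds than this note shows. Statements on the series, on what has been measured and on what is new or still open speak of the compounds shown alone.

Values measured in a functional assay on the whole organism (strain Sprague-Dawley) for inhibition, with Rattus norvegicus as the target, with a stated time of 10 min; a higher number here means that more compound is needed for the effect, a lower number that less compound is needed:

- compound 1 `COc1ccc(OC)c(-c2ncc(C(=O)O)c(=O)[nH]2)c1`: 1 mg/kg
- compound 2 `CCCOc1ccccc1-c1ncc(C(=O)OCC)c(=O)[nH]1`: 5 mg/kg
- compound 3 `CCOC(=O)c1cnc(-c2cc(OC)ccc2OC)[nH]c1=O`: 5 mg/kg

Compound 3 gives 5 mg/kg, and compound 2 shows the same number, so these two share the highest number of the set. Compound 1 has the lowest number, and more compound is needed for the effect once the acid becomes the ethyl ester: a 5.0-fold higher number from compound 1 to compound 3 (0.70 log units; beyond the scatter).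

The next compound is compound 4 `CCCOc1ccc(OC)cc1-c1ncc(C(=O)OCC)c(=O)[nH]1`, which has not yet been measured in this assay. It arises from compound 3 through (ethyl in place of hydrogen on a saturated chain carbon bound to an oxygen on an aromatic ring), in words ethyl in place of hydrogen on a saturated chain carbon bound to an oxygen on an aromatic ring, so that methoxy becomes propoxy. For the measured compounds named here, the one measured step, a 5.0-fold higher number from compound 1 to compound 3 (0.70 log units; beyond the scatter), lies at the ester and not at this place, so it gives no direct measure of the change. Going by the values given here, no measured step covers methoxy to propoxy. Among the compounds with values here, the nearest evidence is compound 2, the only measured compound with a propoxy group, whose value of 5 mg/kg matches that of compound 3. No shift beyond the scatter is therefore expected, and the estimated change is a 1.3-fold lower number from compound 3 to compound 4 (0.10 log units; within the scatter). The expected value for compound 4 is 4 mg/kg, with an estimated range of 1.5 mg/kg to 10 mg/kg.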

Compound 4, dose for 50% inhibition: 0.7 mg/kg
Compound 4: middle estimate off by 5.7-fold (0.76 log units), on the high side, outside the stated range (below it).
By their numbers in this assay, from the lowest: compounds 4 and 1 (each within the scatter of the next); then compounds 2 and 3 (each within the scatter of the next).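

In this assay, the change from methoxy to propoxy on a saturated chain carbon bound to an oxygen on an aromatic ring can now be read directly, and it is not silent: the result is a 7.1-fold lower number from compound 3 to compound 4 (0.85 log units; beyond the scatter), so this place responds to chain length in this pair. The second step reads the other way round, with the propoxy group held constant and methoxy in place of hydrogen on an aromatic carbon, and there the result is a 7.1-fold lower number from compound 2 to compound 4 (0.85 log units; beyond the scatter), so the lower number of compound 4 is tied to both of its ether groups. For the compounds shown here, the earlier compounds had only one step, a 5.0-fold higher number from compound 1 to compound 3 (0.70 log units; beyond the scatter), which lay at the ester and said nothing about either ether group.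

Nothing at hand accounts for the size or direction of these two steps. On these data alone, whether the trend goes on to a longer chain such as butoxy, stops at ethoxy, or survives an amine at the end of the chain stays open, as does the effect of a carboxylic acid in place of the ethyl ester on compound 4.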